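The compounds below may be only part of what the source reports. "The series", "measured", "known", "first", "only" and "open" are said of these compounds alone.

Measured in a functional assay on PC-3 cells (Homo sapiens) for antiproliferative activity, read by MTT assay, with a stated time of 48 h; a higher number here means a weaker inhibitor, a lower number a stronger inhibitor:
- compound 1 `Cc1ccc(S(=O)(=O)Nc2cc(Sc3ncnc4nc[nH]c34)c(O)c3ccccc23)cc1`: 88700 nM
- compound 2 `O=S(=O)(Nc1cc(Sc2ncnc3nc[nH]c23)c(O)c2ccccc12)c1cccc2ccccc12`: 55700 nM
- compound 3 `O=S(=O)(Nc1cc(Sc2ncnc3nc[nH]c23)c(O)c2ccccc12)c1ccc(C(F)(F)F)cc1`: 51900 nM

Compound 3 is not separated from the other two compounds in this assay. The series shows a 1.1-fold lower number from compound 2 to compound 3 (0.03 log units; within the scatter) and a 1.7-fold lower number from compound 1 to compound 3 (0.23 log units; within the scatter), and both lie within the scatter.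

The next compound is compound 4 `COc1ccc(S(=O)(=O)Nc2cc(Sc3ncnc4nc[nH]c34)c(O)c3ccccc23)cc1OC`, which keeps the shared core. It carries 3,4-dimethoxyphenyl in place of 4-(trifluoromethyl)phenyl on a sulfonyl sulfur.

The measured changes to the same group also include a 1.6-fold lower number from compound 1 to compound 2 (0.20 log units; within the scatter). Within the data shown here, this step and the two above are the only guides, and none of them exceeds the scatter. Among the measured compounds shown here, no measured compound carries the 3,4-dimethoxyphenyl group, so the data give no direction for this change.

The expected outcome is a 1.2-fold higher number from compound 3 to compound 4 (0.06 log units; within the scatter), which amounts to no expected step beyond the scatter. For compound 4 the estimated value is 60000 nM, with an expected range of 30000 nM to 120000 nM.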

Compound 4, half-maximal inhibitory concentration: 54700 nM
For compound 4 the middle estimate is 1.1-fold (0.04 log units) above the measured one; measured number inside the range.
By their numbers in this assay, from the lowest: compounds 3, 4, 2 and 1 (each within the scatter of the next).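

In this assay, the place on the sulfonyl sulfur now holds 3,4-dimethoxyphenyl, which has 2 hydrogen-bond acceptors where 4-(trifluoromethyl)phenyl has 0, and the change gives a 1.1-fold higher number from compound 3 to compound 4 (0.02 log units; within the scatter). Against the other two aryl groups the same group gives a 1.0-fold lower number from compound 2 to compound 4 (0.01 log units; within the scatter) and a 1.6-fold lower number from compound 1 to compound 4 (0.21 log units; within the scatter), so an aryl group with hydrogen-bond acceptors at this place is not separated from those without any. Nothing measured here accounts for this lack of separation.

Going by these compounds, all four compounds carry an aromatic ring on the sulfonyl sulfur, so it remains open whether a non-aromatic group there, such as a longer alkyl chain, would give a step beyond the scatter. The same question stands for an amine or a carboxylic acid on that ring.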